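A Formyl for a Cyano Group in Compound 4

The source may report more compounds than this note shows. Statements on the series, on what has been measured and on what is new or still open speak of the compounds shown alone.

Measured in an ADME assay on H9 cells (Homo sapiens) for cytotoxicity, read by XTT assay, with a stated time of 6 days; a lower number here means that less compound is tolerated, a higher number that more compound is tolerated:
Compound 1 `Cc1cc(C#N)cc(C)c1Oc1ccc([N+](=O)[O-])c(Nc2ccc(C#N)cc2)c1`: > 65100 nM, a limit
Compound 2 `Cc1cc(C#N)cc(C)c1Oc1cc(Nc2ccc(C#N)cc2)c([N+](=O)[O-])cc1[N+](=O)[O-]`: > 58200 nM, a limit
Compound 3 `Cc1cc(C#N)cc(C)c1Oc1cc(Nc2ccc(C#N)cc2)c(N)cc1[N+](=O)[O-]`: 62700 nM

Compound 2 gives > 58200 nM in this assay, and this is a limit of the assay, not a number. Only compound 3 has a number, at 62700 nM.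

Compound 4 `Cc1cc(C=O)cc(C)c1Oc1cc(Nc2ccc(C#N)cc2)c([N+](=O)[O-])cc1[N+](=O)[O-]` has not yet been measured. It departs from compound 2 by one change, formyl in place of cyano on an aromatic carbon.

Two measured steps are closest to it: a step that the two limits leave unreadable from compound 1 to compound 2 and a step that the limit leaves unreadable from compound 2 to compound 3. Neither gives a readable size, and neither replaces the cyano group, so they bear on this change only loosely. No direction can be drawn from them, and no move beyond the scatter is expected in this assay, though the uncertainty is wide. The estimate for the change is an at least 1.1-fold lower number from compound 2 to compound 4 (0.06 log units; that floor lies within the scatter). Compound 4 is expected at 50000 nM, with an estimated range of 15000 nM to 100000 nM.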

Compound 4, half-maximal cytotoxic concentration: 57900 nM
For compound 4 the middle estimate is 1.2-fold (0.06 log units) below the measured one, within the range that was stated.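

At the aromatic carbon meta to two methyl groups, formyl in place of cyano gives, in this assay, a number no higher from compound 2 to compound 4 (the limit leaves the size open). Among the compounds shown here, none of the earlier steps touched this position, and here the change yields a number, as compound 4 gives 57900 nM. The size of the step still cannot be read because compound 2 stands at a limit, not a number: the limit of > 58200 nM in this assay, at which 1 of the 4 values shown sits.

The compounds shown leave open how a carboxylic acid or an amine at this same position would read in this assay, since formyl is the only replacement for the cyano group here. For the compounds shown here, they also leave open whether formyl in place of cyano would give a readable step on the core of compound 3, which alone among the earlier compounds has a number.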